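The source may hold more compounds than are shown below. What is called first, only, known or untested is meant among the compounds shown, and "the series" means these compounds.

Working notes on the sulfonamide series.

Three compounds carry numbers in a functional assay (trachea) for antagonist activity, with Cavia porcellus as the target; a higher number here means a more potent compound, by a factor of ten per unit of this negative logarithm, a lower number a less potent compound. Compound 1 `COc1cc(C(=O)NS(=O)(=O)c2cccs2)ccc1Cn1ccc2ccc(NC(=O)CC3CCCC3)cc21` gives 9.6 in this assay. Compound 3 `COc1cc(C(=O)NS(=O)(=O)c2ccccc2C)ccc1Cn1ncc2ccc(NC(=O)CC3CCCC3)cc21` gives 10.9 in this assay, and compound 2 `CCCCC(CC)C(=O)Nc1ccc2ccn(Cc3ccc(C(=O)NS(=O)(=O)c4ccc([N+](=O)[O-])cc4)cc3OC)c2c1` gives 7.7 in this assay. Compound 1 thus stands second of the three: the gap to compound 3 lies beyond the scatter, as does the gap down to compound 2. Compounds 2 and 3 each differ from compound 1 in more than one place, so no single-change step can be read from them.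

Compound 4 `COc1cc(C(=O)NS(=O)(=O)c2ccccc2N)ccc1Cn1ccc2ccc(NC(=O)CC3CCCC3)cc21` is not yet measured. It differs from compound 1 in one place: 2-aminophenyl in place of thiophen-2-yl on a sulfonyl sulfur. The rest of the shared core, the methoxy group, the acylsulfonamide link and the cyclopentylacetamide are unchanged.

Among the measured compounds shown here, no measured pair shows this exchange on the sulfonyl sulfur, so its size is unknown here. The two aryl sulfonamides with numbers, compound 2 and compound 3, fall on either side of compound 1, and they carry other changes as well. The step from compound 1 to compound 4 is therefore expected to be small, a number 0.10 log units higher from compound 1 to compound 4 (within the scatter), within the scatter in either direction. Compound 4 is estimated at 9.7, with a range from 8.9 to 10.5.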

Compound 4, negative logarithm of the antagonist equilibrium constant: 9.9
Compound 4: the middle estimate sits 0.20 log units below what was measured; the measured number falls inside the stated range.
By their numbers in this assay, from the lowest: compound 2; then compounds 1 and 4 (each within the scatter of the next); then compound 3.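

In this assay, among the compounds shown here, the exchange on the sulfonyl sulfur reads a number 0.30 log units higher from compound 1 to compound 4 (within the scatter) and gives the only single-change step so far. Until now, the aryl groups at this position could be viewed only through compounds that also differed elsewhere; this pair isolates the position, with the methoxy group, the acylsulfonamide link and the cyclopentylacetamide unchanged. Here, thiophen-2-yl and 2-aminophenyl are not told apart by this assay, even though the exchange moves from a five-membered aromatic ring with one hetero atom to a six-membered aromatic ring of carbon only and brings in a hydrogen-bond donor. No measurement is available that could explain this outcome.

A plain phenyl group on the sulfonyl sulfur would be needed to separate the contribution of the amino group from that of the ring exchange. Also open, as far as these compounds go, is whether a non-aromatic group, such as a methyl group or a longer alkyl chain, or a carboxylic acid on the phenyl ring in place of the amino group, would stay within the scatter of compound 1.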